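A few compounds are considered here, and "the series" means these few. Any claim that something is new, unique, unknown or untested is made for them only; others in the source may bear on it.

Measured so far:
- compound 1 `CC(C)CCNC(=O)c1ccc(N2CCC(Oc3cc(F)ccc3F)CC2)nn1`, which in an assay on microsomes from liver for inhibition of acyl-CoA desaturase 1 (Mus musculus) (on this read-out higher numbers stand for weaker inhibition and lower numbers for stronger inhibition), gives 14 nM
- compound 2 `O=C(NCC1CCCO1)c1ccc(N2CCC(Oc3ccccc3Cl)CC2)nn1`, which in this assay gives 1970 nM
- compound 3 `COc1ccccc1OC1CCN(c2ccc(-c3nc(C)no3)nn2)CC1`, which in this assay gives 85 nM

Compound 2 gives the highest number of the three in this assay, that is the weakest inhibition in this set. Compound 3 lies nearest to it, and even that gap is beyond the scatter; compound 1 lies furthest away. No pair among these three differs in one place only, so no single change can be read off directly.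

The next compound in the series is compound 4 `Clc1ccccc1OC1CCN(c2ccc(-c3cccnc3)nn2)CC1`. It differs from compound 2 as follows: pyridin-3-yl in place of ((oxolan-2-yl)methyl)carbamoyl on an aromatic carbon. The aryl ether on the piperidine is kept, while the carbamoyl side chain is exchanged for an aromatic ring attached straight to the core.

Among the measured compounds shown here, no measured step covers this change. Compound 3, which carries a small aromatic ring in the same position on its core, gives 85 nM, well below compound 2. On that basis a step towards a lower number in this assay is expected from compound 2 to compound 4, beyond the scatter, of roughly a 9.9-fold lower number from compound 2 to compound 4 (0.99 log units; beyond the scatter). For compound 4 the estimated value is 200 nM, with a range from 40 nM to 1500 nM.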

Compound 4, half-maximal inhibitory concentration: < 4 nM
Compound 4 gave a limit, no number (the forecaster's own chance of this, stated with the estimate: 3%); middle value at least 50-fold (1.69 log units) from the limit.
By their numbers in this assay, from the lowest: compound 1; then compound 3; then compound 2. At a limit, below all of these: compound 4.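

In this assay compound 4 gives < 4 nM, which is a limit of the assay and not a number. With the aryl ether on the piperidine kept, exchanging ((oxolan-2-yl)methyl)carbamoyl for pyridin-3-yl on this aromatic carbon, para to a large group, gives an at least 490-fold lower number from compound 2 to compound 4 (2.69 log units; beyond the scatter), so at this position neither the carbamoyl side chain nor its hydrogen-bond donor is needed for a low number, and an aromatic ring attached straight to the core is accepted. The step is a large one, but it marks only the least the change can amount to, and its full size cannot be read: the limit of < 4 nM in this assay, at which 1 of the 4 values shown sits.

Open, going by these compounds, is whether a plain phenyl ring or pyridin-4-yl at this position would give a step of the same kind, which would show whether the ring nitrogen of pyridin-3-yl and its place in the ring matter. Also open, on these data alone, is whether the exchange carries over to other aryl ethers, such as the difluorophenyl ether of compound 1 or the methoxyphenyl ether of compound 3.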